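Cytotoxicity notes: from compound 3 to compound 4

The compounds below may be only part of what the source reports. "The series", "measured", "known", "first", "only" and "open" are said of these compounds alone.

The series is scored in an ADME assay on L02 cells (Homo sapiens) for cytotoxicity, read by MTT assay, with a stated time of 48 h; a lower number here means a stronger inhibitor, a higher number a weaker inhibitor. Compound 1 `O=c1[nH]c2ccccc2cc1-c1nc2cc(F)ccc2[nH]1` gives > 100000 nM, which is a limit of the assay and not a number. Compound 2 `COc1ccc2[nH]c(=O)c(-c3nc4cc(Cl)ccc4[nH]3)cc2c1` gives > 100000 nM in this assay, again a limit rather than a number. Compound 3 `Cc1ccc2[nH]c(=O)c(-c3nc4cc(Cl)ccc4[nH]3)cc2c1` gives > 100000 nM in this assay, also a limit. All three measured values sit at the same limit, as captured by the limit of > 100000 nM in this assay, at which 3 of the 3 values shown sit. Within the data shown here, the only single-point step among them, methyl in place of methoxy on an aromatic carbon, runs a step that the two limits leave unreadable from compound 2 to compound 3 and so carries no readable size. Compound 3 therefore stands at the limit alongside the other two, and nothing in the numbers separates it from them.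

Compound 4 `O=c1[nH]c2ccccc2cc1-c1nc2cc(Cl)ccc2[nH]1` differs from compound 3 by hydrogen in place of methyl on an aromatic carbon. Among the measured compounds shown here, no measured step bears on this change with a readable size; the one available step, a step that the two limits leave unreadable from compound 2 to compound 3, is itself unreadable between two limits. The expectation for compound 4 in this assay is accordingly a step of a number no higher from compound 3 to compound 4 (the limit leaves the size open), none beyond the scatter, with the reading most likely again a limit. Compound 4 is estimated at 100000 nM, with a range from 50000 nM to 200000 nM.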

Compound 4, half-maximal inhibitory concentration: > 100000 nM
Compound 4 was reported as a limit; the forecaster's own chance of this, stated with the estimate: 85%; the middle value lies on the limit itself.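

In this assay compound 4 gives only a limit, as do compound 1, compound 2 and compound 3, so no step among these compounds can be read: the limit of > 100000 nM in this assay, at which 4 of the 4 values shown sit.

The compounds shown leave open how far any of them lies from that limit, and whether swapping the methyl, methoxy, chloro or fluoro groups changes the reading at all.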